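This account rests on a few compounds, and the source may have more. Where it says the series, first, only, none or still open, it means among the compounds named here.

Compound 1 `O=C1CSC(c2c(Cl)cccc2Cl)N1CCN1CCCCC1`: 10%
Compound 2 `O=C1CSC(c2cccc(O)c2)N1CCN1CCCCC1`: 13%

In an ADME assay on Vero cells (Chlorocebus sabaeus) for cytotoxicity, read by neutral red uptake, tested at 1575 ug/mL (on this read-out higher numbers stand for a weaker effect at the one concentration tested and lower numbers for a stronger effect), compound 1 gives 10% and compound 2 gives 13%; the two numbers lie within the scatter of each other, so compound 2 cannot be set apart from compound 1. Compound 3 `O=C1CSC(c2ccc(F)cc2)N1CCN1CCCCC1` has not been measured. It differs from compound 2 by 4-fluorophenyl in place of 3-hydroxyphenyl on a saturated ring carbon. Among the compounds with values here, no step between measured compounds is available to weigh this change. The step of a number 1 percentage points lower from compound 2 to compound 3 (within the scatter) is expected to be none beyond the scatter. Compound 3 is estimated at 12%, with a range from 3% to 30%.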

Compound 3, a percentage reported as activity, at one concentration (the size of the read-out at that concentration, not a potency): 14%
Compound 3: middle estimate off by 2 percentage points, on the low side, and the stated range covers the measured number.
By their numbers in this assay, from the lowest: compounds 1, 2 and 3 (each within the scatter of the next).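

In this assay, within the data shown here, 4-fluorophenyl in place of 3-hydroxyphenyl on the saturated ring carbon gives a number 1 percentage points higher from compound 2 to compound 3 (within the scatter), the first single-place comparison. At this position, a group with 0 hydrogen-bond donors and 0 hydrogen-bond acceptors therefore reads the same as one with 1 of each, within the scatter. No evidence on hand bears on this result.

From the compounds shown here alone, whether any group at this carbon can move the read-out beyond the scatter remains open. An aminophenyl or carboxyphenyl group, or a longer alkyl chain in place of the aromatic ring, would test this.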